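Swapping Bromo for Methoxy on a Shared Core

This account rests on a few compounds, and the source may have more. Where it says the series, first, only, none or still open, it means among the compounds named here.

Of the compounds shown here, three have been tested in a functional assay on the whole organism (Abdomen, strain Swiss albino) with Mus musculus as the target, with stated times of 10 min and 5 min, at a dose of 15 mg/kg by the oral route; on this read-out lower numbers stand for a weaker effect and higher numbers for a stronger effect at the one dose given. Going by the values given here, compound 1 `CN1C(=O)C2ON=C(c3cn(-c4ccccc4)nc3-c3ccc(Cl)cc3)C2C1=O` gives 7.84% and compound 2 `Cc1ccc(N2C(=O)C3ON=C(c4cn(-c5ccccc5)nc4-c4ccc(Cl)cc4)C3C2=O)cc1` gives 22.8%; the one change between them, a number 15 percentage points higher from compound 1 to compound 2 (beyond the scatter), is the only measured step available. Compound 3 `CCOC(=O)c1onc(-c2cn(-c3ccccc3)nc2-c2ccc(Br)cc2)c1C(=O)OCC` gives 12.9%, the second highest of the three numbers, though its gaps to compound 1 and to compound 2 both lie within the scatter. Compound 4 `CCOC(=O)c1onc(-c2cn(-c3ccccc3)nc2-c2ccc(OC)cc2)c1C(=O)OCC` differs from compound 3 by methoxy in place of bromo on an aromatic carbon. The measured step concerns a different place on the shared core, so nothing measured bears directly on this change, and in this assay a step no larger than the scatter is expected, estimated as a number 0.1 percentage points higher from compound 3 to compound 4 (within the scatter). Compound 4 is therefore expected to give about 13%, between 3% and 28%.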

Compound 4, a percentage reported as activity, at one dose (the size of the read-out at that dose, not a potency): 11.4%
The estimate for compound 4 lay 1.6 percentage points above the measured number; low and high end bracket the measured number.
By their numbers in this assay, from the lowest: compounds 1, 4, 3 and 2 (each within the scatter of the next, the first and the last beyond it).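

In this assay, methoxy in place of bromo on the aromatic carbon para to a large group gives a number 1.5 percentage points lower from compound 3 to compound 4 (within the scatter), so the two compounds cannot be told apart. Going by these compounds alone, this is the first step read at this position, as the earlier step concerned a different place on the shared core. No measurement available here explains this result. From the compounds shown here alone, with only bromo and methoxy compared at this position on this core, the effect of an amine, a carboxylic acid or a longer chain there remains open.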